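The compounds below may be only part of what the source reports. "The series", "measured", "known", "first", "only" and "open" are said of these compounds alone.

Measured compounds in a functional assay on MCF7 cells (Homo sapiens) for cytotoxicity, read by sulforhodamine B assay, with a stated time of 48 h; a lower number here means a stronger inhibitor, a higher number a weaker inhibitor:
compound 1 `Cc1ccccc1OS(=O)(=O)c1cccc(NC(=O)NCCCCl)c1` — 27000 nM
compound 2 `CCCc1ccccc1OS(=O)(=O)c1cccc(NC(=O)NCCCCl)c1` — 14000 nM
compound 3 `Cc1ccccc1OS(=O)(=O)c1ccc(NC(=O)NCCCCl)cc1` — 27000 nM

Compound 1 is level with compound 3 at the digits given, and these two share the highest number of the three; compound 2 gives the lowest. Going by the values given here, the only recorded single-point step is a 1.9-fold lower number from compound 1 to compound 2 (0.29 log units; within the scatter), which stays within the scatter and concerns ethyl in place of hydrogen on a saturated chain carbon bound to an aromatic carbon. Between compound 1 and compound 3 no step is recorded; their values show no change at the digits given.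

Compound 4 `Cc1ccccc1NS(=O)(=O)c1cccc(NC(=O)NCCCCl)c1` has not been measured in this assay. It differs from compound 1 in one place: (2-methylphenyl)amino in place of 2-methylphenoxy on a sulfonyl sulfur. Among the compounds with values here, no measured pair in this set exchanges the atom that joins the sulfonyl sulfur to the 2-methylphenyl ring, so no recorded step bears directly on this change, and no direction can be read from the numbers. The expectation is therefore placed close to compound 1, with a wide range to reflect the absence of any guiding step. Compound 4 is estimated at 22000 nM, between 7000 nM and 70000 nM. This estimate means an expected step of a 1.2-fold lower number from compound 1 to compound 4 (0.09 log units; within the scatter).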

Compound 4, half-maximal inhibitory concentration: 52000 nM
For compound 4 the middle estimate is 2.4-fold (0.37 log units) below the measured one; the measured number falls inside the stated range.
By their numbers in this assay, from the lowest: compounds 2, 1, 3 and 4 (each within the scatter of the next, the first and the last beyond it).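

Notes on the atom joining the sulfonyl sulfur to the 2-methylphenyl ring: in this assay, the exchange of 2-methylphenoxy for (2-methylphenyl)amino on a sulfonyl sulfur gives a 1.9-fold higher number from compound 1 to compound 4 (0.28 log units; within the scatter), the first reading at this place in the series, where the earlier step concerned only the chain on the aromatic ring. The entering group has a hydrogen-bond donor and no hydrogen-bond acceptor, the leaving group a hydrogen-bond acceptor and no hydrogen-bond donor, and with this exchange the step stays within the scatter, so this pair shows that the linking oxygen can be replaced by nitrogen without a change that the assay can resolve. No measurement on these compounds accounts for the size of this step.

Still open, from the compounds shown here alone, is whether a methyl group on the linking nitrogen, or a methylene group as the linking unit, would give a step beyond the scatter. Also open, going by these compounds, is whether the ethyl-for-hydrogen change on the chain, read so far only with the oxygen link, gives a similar step on the core of compound 4.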